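The compounds below may be only part of what the source reports. "The series", "measured", "known", "first", "only" and "open" are said of these compounds alone.

In a functional assay on MCF7 cells (Homo sapiens) for cytotoxicity, read by MTT assay (on this read-out lower numbers stand for stronger inhibition and higher numbers for weaker inhibition), three compounds of a shared core have been measured. Compound 1 `COc1ccc(/C=C2\CCC/C(=C\c3ccccc3[N+](=O)[O-])C2=O)cc1` gives 11.2 ug/mL in this assay. Compound 2 `COc1cccc(/C=C2\CCC/C(=C\c3cccc([N+](=O)[O-])c3)C2=O)c1` gives 4.17 ug/mL in this assay. Compound 3 `CCOc1c(Br)cc(/C=C2\CCC/C(=C\c3cccc([N+](=O)[O-])c3)C2=O)cc1OC` gives 24.9 ug/mL in this assay, the highest of the three numbers; the gap to compound 1 lies beyond the usual scatter, and the gap to compound 2 is wider still.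

Compound 4 `CCCCOc1c(Br)cc(/C=C2\CCC/C(=C\c3cccc([N+](=O)[O-])c3)C2=O)cc1OC` is the next compound, not yet measured. Compared with compound 3 it carries ethyl in place of hydrogen on a saturated chain carbon, two bonds along the chain from an oxygen on an aromatic ring; read from the ring outward, the ethoxy group becomes a butoxy group. Going by the values given here, none of the measured pairs shows a change of this kind, so nothing on record tells its direction. A lengthening of a chain of this sort is expected to move the number little, with no step beyond the scatter in either direction.

For compound 4 the expected step is a 1.0-fold higher number from compound 3 to compound 4 (0.00 log units; within the scatter) in this assay. The estimate for compound 4 in this assay is 25 ug/mL, within a range from 10 ug/mL to 60 ug/mL.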

Compound 4, half-maximal inhibitory concentration: 5.97 ug/mL
Compound 4: middle estimate off by 4.2-fold (0.62 log units), on the high side; measured number outside the range, below it.
By their numbers in this assay, from the lowest: compounds 2, 4 and 1 (each within the scatter of the next, the first and the last beyond it); then compound 3.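

The chain on the aromatic oxygen is not a silent spot: in this assay the change from ethoxy to butoxy gives a 4.2-fold lower number from compound 3 to compound 4 (0.62 log units; beyond the scatter). Going by these compounds alone, this is the first step on record between two compounds that differ in only one place, and so the first direct sign that the length of this chain alone can shift the number, here toward stronger inhibition. Nothing on record explains why the longer chain has this effect.

The compounds shown leave open whether the number keeps falling with a still longer chain such as hexyloxy, or turns back up again. One step also cannot tell whether a branched isopropoxy group, or a chain ending in an amine, would behave as butoxy does.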